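The source may hold more compounds than are shown below. What is called first, only, known or untested is meant among the compounds shown, and "the series" means these compounds.

Measured compounds:
compound 1, `NCCCc1c[nH]c2c(F)cccc12`, 24 nM
compound 2, `NCCCCc1c[nH]c2c(F)cccc12`, 6 nM

In an assay on isolated protein (urine) for inhibition of Myeloperoxidase (Homo sapiens), with a stated time of 5 min (a lower number here means a stronger inhibitor, a higher number a weaker inhibitor), compound 2 gives 6 nM, the lowest of the two numbers seen; its nearest neighbour is compound 1, which in this assay gives 24 nM. Among the measured compounds shown here, the only measured step connects these two: a 4.0-fold lower number from compound 1 to compound 2 (0.60 log units; beyond the scatter), a change that lengthens the saturated chain between the core and the amino group by one carbon.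

Compound 3, `NCCSCCCc1c[nH]c2c(F)cccc12`, is still to be measured. Relative to compound 2 the change is (2-aminoethyl)sulfanyl in place of aminomethyl on a saturated chain carbon, three bonds along the chain from an aromatic carbon. Again the chain carrying the amino group grows longer, now with a sulfur in it, so the step from compound 1 to compound 2 is the one measured step that bears on it. That step was modest and beyond the scatter, in the direction of a lower number; whether further lengthening, with sulfur in the chain, continues in that direction is not settled by one step, and a reversal is as conceivable as a continuation. Compound 3 is therefore expected to give about 10 nM, within 2.5 nM to 40 nM, a step of a 1.7-fold higher number from compound 2 to compound 3 (0.22 log units; within the scatter) that is expected to stay within the scatter.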

Compound 3, half-maximal inhibitory concentration: > 100 nM
Compound 3: a limit, no number (the forecaster's own chance of this, stated with the estimate: 0%); middle value at least 10-fold (1.00 log units) away from the limit.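

In this assay compound 3 is reported only as a limit and not as a number: the limit of > 100 nM in this assay, at which 1 of the 3 values shown sits.

Even so, the limit is enough to show that the direction seen on the first lengthening does not hold for (2-aminoethyl)sulfanyl on a saturated chain carbon, three bonds along the chain from an aromatic carbon, since the result is an at least 16-fold higher number from compound 2 to compound 3 (1.22 log units; beyond the scatter). The new group also falls behind the shorter amino chain, with an at least 4.1-fold higher number from compound 1 to compound 3 (0.61 log units; beyond the scatter), so among these three compounds a longer chain does not by itself give a lower number, and compound 3 is the one that goes against the direction of the first step.

This change adds chain length and a sulfur at once, so the compounds shown leave open which of the two goes with the higher number; an all-carbon chain of the same length, or an oxygen in place of the sulfur, would separate them. As far as these compounds go, how far past its limit compound 3 lies also stays open, as does the point at which a plain carbon chain carrying the amine would stop giving a lower number.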